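Thiophen-3-yl versus benzofuran-2-yl on the nucleoside core

A few compounds are considered here, and "the series" means these few. Any claim that something is new, unique, unknown or untested is made for them only; others in the source may bear on it.

Measured compounds:
compound 1 `COc1ncnc2c1c(-c1ccsc1)cn2[C@@H]1O[C@H](CO)[C@@H](O)[C@H]1O`: 75300 nM
compound 2 `C#Cc1cn([C@@H]2O[C@H](CO)[C@@H](O)[C@H]2O)c2ncnc(C)c12`: 1440 nM
compound 3 `Cc1ncnc2c1c(-c1cc3ccccc3o1)cn2[C@@H]1O[C@H](CO)[C@@H](O)[C@H]1O`: 84400 nM

In an ADME assay on MRC5 cells (Homo sapiens), read by MTT assay, with a stated time of 72 h (on this read-out lower numbers stand for stronger inhibition and higher numbers for weaker inhibition), compound 3 gives the highest of the three numbers; compound 1 lies within the scatter of it, while compound 2 lies far beyond. Within the data shown here, the one measured step that touches this position is a 59-fold higher number from compound 2 to compound 3 (1.77 log units; beyond the scatter), a large rise in number on going from ethynyl to 1-benzofuran-2-yl.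

Compound 4 `Cc1ncnc2c1c(-c1ccsc1)cn2[C@@H]1O[C@H](CO)[C@@H](O)[C@H]1O` is not yet measured. It arises from compound 3 by thiophen-3-yl in place of 1-benzofuran-2-yl on an aromatic carbon. Among the measured compounds shown here, no measured step covers this exact swap. The large step of a 59-fold higher number from compound 2 to compound 3 (1.77 log units; beyond the scatter) shows that the smaller group at this carbon went with the lower number, and thiophen-3-yl is smaller than 1-benzofuran-2-yl. Thiophen-3-yl is also carried by compound 1, which differs from compound 4 in one other group on the shared core; in this assay compound 1 gives 75300 nM, a high number. Compound 4 is therefore expected to show a modest fall, a 2.1-fold lower number from compound 3 to compound 4 (0.32 log units; beyond the scatter). The estimate for compound 4 is 40000 nM, with a range from 8000 nM to 120000 nM.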

Compound 4, half-maximal inhibitory concentration: > 100000 nM
Compound 4: a limit, no number; the forecaster's own chance of this, stated with the estimate: 10%; at least 2.5-fold (0.39 log units) between middle value and limit.
By their numbers in this assay, from the lowest: compound 2; then compounds 1 and 3 (each within the scatter of the next). At a limit, above all of these: compound 4.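

In this assay, compound 4 gives a limit of the assay, not a number: the limit of > 100000 nM in this assay, at which 1 of the 4 values shown sits.

The trend suggested by the earlier step, in which the smaller group went with the lower number, does not carry over to thiophen-3-yl: the change to compound 4 gives an at least 69-fold higher number from compound 2 to compound 4 (1.84 log units; beyond the scatter), so the low number of compound 2 remains confined to ethynyl among the groups shown, and compound 4 goes against any simple link with group size. The other two steps, an at least 1.1-fold higher number from compound 3 to compound 4 (0.07 log units; that floor lies within the scatter) and an at least 1.3-fold higher number from compound 1 to compound 4 (0.12 log units; that floor lies within the scatter), separate neither the two aromatic groups nor methyl and methoxy on the shared core.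

As far as these compounds go, the true distance of compound 4 from compound 1 and compound 3 remains open. Also open, from the compounds shown here alone, is whether the low number belongs to ethynyl alone or extends to other compact groups at this carbon, such as a nitrile or an aminomethyl group.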